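Aziridine Carbonitrile Ureas: Fluoro Replaced by Trifluoromethyl

The compounds below may be only part of what the source reports. "The series", "measured", "known", "first", "only" and "open" are said of these compounds alone.

Three ureas built on the shared core have been measured in a functional assay on A549 cells (Homo sapiens) for inhibition; a lower number here means a stronger inhibitor, a higher number a weaker inhibitor. Compound 1 `CCCCNC(=O)N1CC1C#N` gives 18000 nM. Compound 2 `N#CC1CN1C(=O)Nc1ccc(F)cc1` gives 6200 nM, and compound 3 `N#CC1CN1C(=O)Nc1ccc(Cl)cc1Cl` gives 2500 nM. Compound 2 thus stands second highest of the three numbers: compound 3 gives a lower number, beyond the scatter, while compound 1 gives a higher one, further away and also beyond the scatter. Compound 4 `N#CC1CN1C(=O)Nc1ccc(C(F)(F)F)cc1` has not yet been measured; it differs from compound 2 by trifluoromethyl in place of fluoro on an aromatic carbon. Going by the values given here, no step between measured compounds covers such a change. The step from compound 2 to compound 4 is expected to be modest, toward a lower number, a 1.8-fold lower number from compound 2 to compound 4 (0.25 log units; within the scatter). Compound 4 is estimated at 3500 nM, within 1200 nM to 10000 nM.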

Compound 4, half-maximal inhibitory concentration: 4300 nM
Compound 4: the middle estimate sits 1.2-fold (0.09 log units) below what was measured; measured number inside the range.
By their numbers in this assay, from the lowest: compounds 3, 4 and 2 (each within the scatter of the next, the first and the last beyond it); then compound 1.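

In this assay, the step with trifluoromethyl in place of fluoro on this aromatic carbon reads a 1.4-fold lower number from compound 2 to compound 4 (0.16 log units; within the scatter). Going by these compounds alone, this is the first one-place comparison, and it shows that, at this position, going from fluoro to the larger trifluoromethyl leaves compound 2 and compound 4 within the scatter of each other. Nothing available bears on why this is so.

The compounds shown leave open whether an amine or a carboxylic acid on this same carbon would also stay within the scatter of compound 2.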